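This account rests on a few compounds, and the source may have more. Where it says the series, first, only, none or still open, it means among the compounds named here.

Among the compounds with values here, in a functional assay on A549 cells (Homo sapiens) for antiproliferative activity, read by MTT assay, with a stated time of 72 h (on this read-out higher numbers stand for weaker inhibition and lower numbers for stronger inhibition), compound 2 `CN1CCN(Cc2ccc(NC(=O)Nc3ccc4ncnc(Nc5cccc(C(F)(F)F)c5)c4c3)cc2)CC1` gives 1650 nM, the only true number among the three measured compounds. Compound 1 `CN1CCN(Cc2ccc(NC(=O)Nc3ccc4ncnc(Nc5ccc(F)c(F)c5)c4c3)cc2)CC1` returns only the assay limit > 10000 nM. Compound 3 `COC(=O)c1cccc(Nc2ncnc3ccc(NC(=O)Nc4ccc(CN5CCN(C)CC5)cc4)cc23)c1` likewise returns only the limit > 10000 nM. Both of these sit at the limit of > 10000 nM in this assay, at which 2 of the 3 values shown sit. Compound 4 `CCN(CC)Cc1ccc(NC(=O)Nc2ccc3ncnc(Nc4cccc(C(F)(F)F)c4)c3c2)cc1` differs from compound 2 in one place: diethylamino in place of 4-methylpiperazin-1-yl on a saturated chain carbon bound to an aromatic carbon. Every measured step instead alters the group on a nitrogen on an aromatic ring: an at least 6.0-fold lower number from compound 1 to compound 2 (0.78 log units; beyond the scatter), an at least 6.0-fold higher number from compound 2 to compound 3 (0.78 log units; beyond the scatter), and a step that the two limits leave unreadable from compound 1 to compound 3. Within the data shown here, none of them touches the part that changes in compound 4, so no measured step bears on it. The expected outcome is a 1.0-fold higher number from compound 2 to compound 4 (0.01 log units; within the scatter), nothing beyond the scatter. Compound 4 is therefore estimated at 1700 nM, within 600 nM to 5000 nM.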

Compound 4, half-maximal inhibitory concentration: 2070 nM
The estimate for compound 4 lay 1.2-fold (0.09 log units) below the measured number; the range from low to high includes it.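

In this assay, the step of a 1.3-fold higher number from compound 2 to compound 4 (0.10 log units; within the scatter) is the first shown at this position, a saturated chain carbon bound to an aromatic carbon, whereas the earlier steps all altered the group on a nitrogen on an aromatic ring. With 3-(trifluoromethyl)phenyl held constant, the open diethylamino group can stand in for the 4-methylpiperazin-1-yl ring with no change beyond the scatter. The compounds shown offer no reason for this outcome.

Going by these compounds, it remains open whether a morpholine ring, a primary amine or a longer chain carrying the amine would fare alike at this position. On these data alone, it also remains open whether diethylamino would behave the same alongside 3,4-difluorophenyl or 3-(methoxycarbonyl)phenyl.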